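The compounds below may be only part of what the source reports. "The series", "measured", "known", "first", "only" and "open" are said of these compounds alone.

Of the compounds shown here, two have numbers so far. In a functional assay on SW 1116 cells (Homo sapiens) for antiproliferative activity, read by MTT assay, with a stated time of 48 h (on this read-out higher numbers stand for weaker inhibition and lower numbers for stronger inhibition), compound 1 `O=[N+]([O-])c1cccc(CSc2nnc(-c3ccc4c(c3)OCCO4)o2)c1` gives 30100 nM as its reading, and compound 2 `Brc1ccccc1CSc1nnc(-c2ccc3c(c2)OCCO3)o1` gives 14100 nM as its reading. Compound 2 therefore holds the lower of the two numbers, which means the stronger inhibition of the pair, and the gap lies beyond the usual scatter of repeat measurements.

Compound 3 `Clc1ccccc1CSc1nnc(-c2ccc3c(c2)OCCO3)o1` has not been measured yet. It differs from compound 2 in one place only, where chloro in place of bromo on an aromatic carbon sums up the swap: chloro in place of bromo on an aromatic carbon, so that 2-bromobenzyl becomes 2-chlorobenzyl. Among the compounds with values here, no measured pair shows this swap directly, so the expectation rests on the change itself, which involves no ring and no net charge. Starting from compound 2 at 14100 nM on this read-out, the expected step in this assay is none beyond the scatter, with no favoured direction. The estimated move is small, a 1.1-fold higher number from compound 2 to compound 3 (0.03 log units; within the scatter) and stays inside that scatter. For compound 3 the estimated value is 15000 nM with an expected range from 6500 nM to 34000 nM on repeat measurement.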

Compound 3, half-maximal inhibitory concentration: 29500 nM
For compound 3 the middle estimate is 2.0-fold (0.29 log units) below the measured one; measured number inside the range.
By their numbers in this assay, from the lowest: compound 2; then compounds 3 and 1 (each within the scatter of the next).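

In this assay the series now has its first pair that differs in one place: going from 2-bromobenzyl to 2-chlorobenzyl gives a 2.1-fold higher number from compound 2 to compound 3 (0.32 log units; beyond the scatter) and so shows that exchanging one halogen for the other on this aromatic carbon is not neutral, although the step is only modest. Bromo and chloro have the same counts, with one heavy atom each, no ring, no hydrogen-bond donors or acceptors and no net charge, so these counts alone do not separate the two compounds. Nothing in the available information explains why the bromo compound gives the lower number.

This single pair cannot show whether the difference between bromo and chloro would persist with a different core or with the halogen at another place on the ring. It also leaves open how a fluoro, methyl or methoxy group on the same carbon would read, and whether an amine or a carboxylic acid there would be tolerated at all.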